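This account rests on a few compounds, and the source may have more. Where it says the series, first, only, none or still open, it means among the compounds named here.

Values in an ADME assay on Vero cells (Chlorocebus sabaeus) for cytotoxicity, read by MTT assay (on this read-out higher numbers stand for weaker inhibition and lower numbers for stronger inhibition), are as follows:
compound 1 `Cc1nc(C(=O)OC2CC2)c(N)c2c1C(=O)N(Cc1ccccc1)C2=O` gives "not determined" (no result reported)
compound 2 `Cc1nc(C(N)=O)c(N)c2c1C(=O)N(Cc1ccccc1)C2=O` gives "not determined" (no result reported)
compound 3 `Cc1nc(C(=O)N(C)C)c(N)c2c1C(=O)N(Cc1ccccc1)C2=O` gives > 100000 nM

Compound 1 has no number to stand on in this assay, and compound 2 has none either. Among the measured compounds shown here, the only reading in this small set is that of compound 3. Compound 3 gives > 100000 nM, which is a limit of the assay and not a number. For the measured compounds named here, the evidence therefore comes to a single entry, (the limit of > 100000 nM in this assay, at which 1 of the 3 values shown sits), and it gives no measured step between any two compounds.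

The next compound for testing is compound 4 `Cc1nnc(-c2nc(C)c3c(c2N)C(=O)N(Cc2ccccc2)C3=O)o1`. The structural change is 5-methyl-1,3,4-oxadiazol-2-yl in place of cyclopropyloxycarbonyl on an aromatic carbon. In words, 5-methyl-1,3,4-oxadiazol-2-yl takes the place of cyclopropyloxycarbonyl on an aromatic carbon, ortho to the amino group, with the rest of the core of compound 1 unchanged.

With no starting number for compound 1, the size of this step in this assay can only be expected, and the expectation is no change beyond the usual scatter, in either direction. Going by the values given here, the one anchor is compound 3 at > 100000 nM, so a reading at the same limit is the likeliest outcome for the new compound.

For compound 4 the estimated value is 100000 nM, with an expected range from 40000 nM to 200000 nM.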

Compound 4, half-maximal inhibitory concentration: > 100000 nM
Compound 4: no number, only a limit (the forecaster's own chance of this, stated with the estimate: 70%); the middle value lies on the limit itself.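

In this assay, compound 3 and compound 4 both give a limit and not a number, and compound 1 gives no number, so no step can be read from compound 3 or compound 1 to compound 4. The compounds shown leave open whether 5-methyl-1,3,4-oxadiazol-2-yl, dimethylcarbamoyl or cyclopropyloxycarbonyl on the shared core makes any difference in this assay.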